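A nitrile enters a series with little spread

The source may hold more compounds than are shown below. What is called first, only, known or untested is meant among the compounds shown, and "the series" means these compounds.

In a functional assay, read by spectrophotometry, with a stated time of 30 min (a lower number here means a stronger inhibitor, a higher number a weaker inhibitor), compound 1 `Cc1ccc(CN2CCC(CCNC(=O)/C=C/c3cc(C(C)(C)C)c(O)c(C(C)(C)C)c3)CC2)cc1` gives 60400 nM and compound 2 `CC(C)(C)c1cc(/C=C/C(=O)NCCC2CCN(Cc3ccc(F)cc3)CC2)cc(C(C)(C)C)c1O` gives 57500 nM while compound 3 `CC(C)(C)c1cc(/C=C/C(=O)NCCC2CCN(Cc3cccc(Cl)c3)CC2)cc(C(C)(C)C)c1O` gives 83100 nM and so stands within the scatter of both. Compound 4 `CC(C)(C)c1cc(/C=C/C(=O)NCCC2CCN(Cc3ccc(C#N)cc3)CC2)cc(C(C)(C)C)c1O` differs from compound 3 by 4-cyanophenyl in place of 3-chlorophenyl on a saturated chain carbon bound to an amine nitrogen in a ring. The steps of a 1.4-fold higher number from compound 1 to compound 3 (0.14 log units; within the scatter) and a 1.4-fold higher number from compound 2 to compound 3 (0.16 log units; within the scatter) changed this same place, and a 1.1-fold lower number from compound 1 to compound 2 (0.02 log units; within the scatter) came with fluoro in place of methyl. For the measured compounds named here, all three lie within the scatter, although no measured compound carries a nitrile. The estimated step of a 1.3-fold lower number from compound 3 to compound 4 (0.11 log units; within the scatter) is therefore small, with nothing beyond the scatter expected. For compound 4 the estimate is 65000 nM (expected range 30000 nM to 130000 nM).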

Compound 4, half-maximal inhibitory concentration: 79500 nM
Compound 4: middle estimate off by 1.2-fold (0.09 log units), on the low side; the range from low to high includes it.
By their numbers in this assay, from the lowest: compounds 2, 1, 4 and 3 (each within the scatter of the next).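

In this assay 4-cyanophenyl takes the place of 3-chlorophenyl with a 1.0-fold lower number from compound 3 to compound 4 (0.02 log units; within the scatter) and cyano takes the place of fluoro with a 1.4-fold higher number from compound 2 to compound 4 (0.14 log units; within the scatter) and of methyl with a 1.3-fold higher number from compound 1 to compound 4 (0.12 log units; within the scatter) in the same series. So a group with a triple bond outside aromatic rings, new to these compounds, stays within the scatter of all three at this place. No measurement at hand explains this result. Still open, on these data alone, is whether an amine or a carboxylic acid on the phenyl ring, or a longer chain in place of the benzyl carbon, would move the number beyond the scatter.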